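Swapping isopropyl for trifluoromethyl on the pendant aryl ring

A few compounds are considered here, and "the series" means these few. Any claim that something is new, unique, unknown or untested is made for them only; others in the source may bear on it.

Compound 1 `COC(=O)c1ccc2c(c1)S(=O)(=O)N=S2c1ccc(Br)cc1`: 4100 nM
Compound 2 `CCc1ccc(S2=NS(=O)(=O)c3cc([N+](=O)[O-])ccc32)cc1`: 180 nM
Compound 3 `CC(C)c1ccc(S2=NS(=O)(=O)c3cc([N+](=O)[O-])ccc32)cc1`: 360 nM

All three were tested in an assay on isolated protein for inhibition of Polyunsaturated fatty acid 5-lipoxygenase (Homo sapiens), read by immunoassay, with a stated time of 15 min; on this read-out higher numbers stand for weaker inhibition and lower numbers for stronger inhibition. Compound 3 stands second highest of the three numbers. Its nearest neighbour is compound 2, with a 2.0-fold higher number from compound 2 to compound 3 (0.30 log units; within the scatter); compound 1 lies much higher, beyond the scatter.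

Compound 4 `O=[N+]([O-])c1ccc2c(c1)S(=O)(=O)N=S2c1ccc(C(F)(F)F)cc1` has not yet been measured. It differs from compound 3 by trifluoromethyl in place of isopropyl on an aromatic carbon. Within the data shown here, no measured step makes this kind of exchange. Among the measured compounds shown here, the only step touching that group, a 2.0-fold higher number from compound 2 to compound 3 (0.30 log units; within the scatter), shows that a small alteration there left the number within the scatter. Only a small step is therefore expected, a 1.2-fold lower number from compound 3 to compound 4 (0.08 log units; within the scatter), with no firm direction. Compound 4 is estimated at 300 nM, within a range from 100 nM to 900 nM.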

Compound 4, half-maximal inhibitory concentration: 3090 nM
For compound 4 the middle estimate is 10-fold (1.01 log units) below the measured one; the measured number lies above the stated range.
By their numbers in this assay, from the lowest: compounds 2 and 3 (each within the scatter of the next); then compounds 4 and 1 (each within the scatter of the next).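

The position is less forgiving than the ethyl and isopropyl pair suggested. In this assay the exchange of isopropyl for trifluoromethyl gives an 8.6-fold higher number from compound 3 to compound 4 (0.93 log units; beyond the scatter) and the exchange of ethyl for trifluoromethyl gives a 17-fold higher number from compound 2 to compound 4 (1.23 log units; beyond the scatter), so this replacement clearly weakens inhibition. No measurement shown here accounts for the loss. The compounds shown leave open how a methoxy group, a nitrile or a longer chain would fare at this place. They also leave open whether trifluoromethyl would have the same effect on the core of compound 1.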